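The compounds below may be only part of what the source reports. "The series", "measured", "known", "first", "only" and "open" are said of these compounds alone.

Among the compounds with values here, compound 3 `CCCCCNC(=O)NS(=O)(=O)c1cc(C#N)ccc1Nc1ccccc1C` gives 3190 nM in a functional assay on HEK293 cells for antagonist activity at thromboxane A2 receptor (Homo sapiens), read by fluorescence and calcium flux (on this read-out higher numbers stand for weaker inhibition and lower numbers for stronger inhibition), the highest of the three numbers so far: compound 1 `CCCCCNC(=O)NS(=O)(=O)c1cc(C#N)ccc1Oc1ccccc1C` gives 2240 nM and compound 2 `CCCCCNC(=O)NS(=O)(=O)c1cc(C#N)ccc1Oc1cccc(C)c1` gives 1330 nM. Compound 4 `CCCCCNC(=O)NS(=O)(=O)c1cc(C#N)ccc1Nc1ccc(F)cc1` differs from compound 3 by 4-fluorophenyl in place of 2-methylphenyl on a nitrogen on an aromatic ring. Within the data shown here, no measured step exchanges a methyl for a fluorine on this aryl group; the nearest precedent is the relocation of the methyl on the aryl on oxygen, a 1.7-fold lower number from compound 1 to compound 2 (0.23 log units; within the scatter), and the only other steps are a 1.4-fold higher number from compound 1 to compound 3 (0.15 log units; within the scatter) and a 2.4-fold higher number from compound 2 to compound 3 (0.38 log units; beyond the scatter). None of these exceeds a modest size, so the step of a 1.1-fold lower number from compound 3 to compound 4 (0.03 log units; within the scatter) is expected to stay within the scatter, with no direction the series supports. Compound 4 is therefore expected near 3000 nM, between 1200 nM and 7500 nM.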

Compound 4, half-maximal inhibitory concentration: 6780 nM
The estimate for compound 4 lay 2.3-fold (0.35 log units) below the measured number, within the range that was stated.
By their numbers in this assay, from the lowest: compounds 2, 1 and 3 (each within the scatter of the next, the first and the last beyond it); then compound 4.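

On the aryl group on the nitrogen, 4-fluorophenyl in place of 2-methylphenyl gives a 2.1-fold higher number from compound 3 to compound 4 (0.33 log units; beyond the scatter) in this assay and so moves the number beyond the scatter. The aryl ethers lie further off, with a 3.0-fold higher number from compound 1 to compound 4 (0.48 log units; beyond the scatter) and a 5.1-fold higher number from compound 2 to compound 4 (0.71 log units; beyond the scatter), which makes compound 4 the weakest inhibitor of the four. No available evidence accounts for this shift.

Unsubstituted phenyl or 4-methylphenyl on the nitrogen would separate loss of the 2-methyl group from entry of the fluorine. A 4-fluorophenoxy analogue would test whether the oxygen link tolerates this group better.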